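Methoxy removal on the fused ring of compound 1

The source may hold more compounds than are shown below. What is called first, only, known or untested is meant among the compounds shown, and "the series" means these compounds.

Compound 1 `COc1ccc2c(c1)C/C(=C\c1cc(-c3cc(OC)c(OC)c(OC)c3)n[nH]1)C2=O`: 2000 nM
Compound 2 `COc1ccc(C(=O)/C=C/c2cc(-c3cc(OC)c(OC)c(OC)c3)n[nH]2)cc1OC`: 620 nM
Compound 3 `COc1cc2c(cc1OC)C(=O)/C(=C/c1cc(-c3cc(OC)c(OC)c(OC)c3)n[nH]1)C2`: 2500 nM

In a functional assay on MDA-MB-231 cells (Homo sapiens) for inhibition, read by MTT assay, with a stated time of 48 h (on this read-out higher numbers stand for weaker inhibition and lower numbers for stronger inhibition), compound 1 stands second highest of the three numbers; compound 3 lies nearest, within the scatter, while compound 2 gives the lowest number of the set, beyond the scatter from compound 1.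

Compound 4 `COc1cc(-c2cc(/C=C3\Cc4ccccc4C3=O)[nH]n2)cc(OC)c1OC` is not yet measured. It differs from compound 1 by hydrogen in place of methoxy on an aromatic carbon.

For the measured compounds named here, the only step that bears on this is the mirror one, a 1.3-fold higher number from compound 1 to compound 3 (0.10 log units; within the scatter), where adding a methoxy on the same ring changed nothing beyond the scatter. Removing one is therefore expected to give no step beyond the scatter either, a 1.3-fold higher number from compound 1 to compound 4 (0.11 log units; within the scatter).

Compound 4 is estimated at 2600 nM, with a range of 1100 nM to 7000 nM.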

Compound 4, half-maximal inhibitory concentration: 7100 nM
Compound 4: middle estimate off by 2.7-fold (0.44 log units), on the low side; measured number outside the range, above it.
By their numbers in this assay, from the lowest: compound 2; then compounds 1 and 3 (each within the scatter of the next); then compound 4.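

In this assay the methoxy on the fused ring of compound 1 is not interchangeable with hydrogen: removing it gives a 3.6-fold higher number from compound 1 to compound 4 (0.55 log units; beyond the scatter) while adding a further methoxy on that ring gave only a 1.3-fold higher number from compound 1 to compound 3 (0.10 log units; within the scatter) in the earlier pair. The two changes are therefore not mirror images at this ring. No measurement shown accounts for this difference.

Still open, on these data alone, is whether a replacement such as hydroxy, fluorine or ethoxy at this place would keep the number of compound 1 or follow compound 4.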